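The source may report more compounds than this note shows. Statements on the series, on what has been measured and on what is new or still open speak of the compounds shown alone.

The study concerns a set of pyrazole-based compounds that share one core and differ in the amide or urea that hangs from the aniline nitrogen. Compound 1 `COc1cc(-c2nn(-c3cccc(NC(=O)c4ccc(Cl)c(C(F)(F)F)c4)c3)cc2-c2ccncc2)ccc1Cl` carries an amide; in a functional assay on MCF7 cells (Homo sapiens) for inhibition, read by sulforhodamine B assay, with a stated time of 48 h (on this read-out lower numbers stand for stronger inhibition of growth and higher numbers for weaker inhibition of growth), compound 1 gives only a limit, > 32500 nM. Compound 3 `COc1cc(-c2nn(-c3cccc(NC(=O)Nc4cccc(C(F)(F)F)c4)c3)cc2-c2ccncc2)ccc1Cl` carries a urea instead, and in this assay compound 3 gives 7720 nM. That change gave an at least 4.2-fold lower number from compound 1 to compound 3 (0.62 log units; beyond the scatter). Compound 2 `O=C(Nc1cccc(-n2cc(-c3ccncc3)c(-c3ccc(Cl)c(O)c3)n2)c1)Nc1cc(C(F)(F)F)cc(C(F)(F)F)c1` has a hydroxy group on the distal aryl ring rather than a methoxy and a second trifluoromethyl group on the urea aryl; in this assay compound 2 gives 5790 nM, which sits within the scatter of the number for compound 3. Among the two numbers shown, compound 3 therefore lies on a par with compound 2.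

Compound 4 `COc1cc(-c2nn(-c3cccc(NC(=O)Nc4cc(C(F)(F)F)cc(C(F)(F)F)c4)c3)cc2-c2ccncc2)ccc1Cl` is the next step: trifluoromethyl in place of hydrogen on an aromatic carbon. Among the measured compounds shown here, no measured step matches this change directly. For the measured compounds named here, the only measured step, the one from compound 1 to compound 3, concerns the amide-to-urea exchange and says nothing about a second trifluoromethyl group. The pair of compound 2 and compound 3 differs in two places at once, yet their values lie within the scatter of each other, which suggests the added trifluoromethyl group carries little weight here. Compound 4 is therefore expected to show a 1.3-fold lower number from compound 3 to compound 4 (0.12 log units; within the scatter), a step no larger than the scatter. The estimate for compound 4 in this assay is 5800 nM, in a range from 2500 nM to 14000 nM.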

Compound 4, concentration for total growth inhibition: 10900 nM
Estimate against measurement, compound 4: 1.9-fold (0.27 log units) below, within the range that was stated.
By their numbers in this assay, from the lowest: compounds 2, 3 and 4 (each within the scatter of the next). At a limit, above all of these: compound 1.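

In this assay, compound 2 and compound 3 differ in two places, so they could not separate the two changes, but the new pairs each isolate one. Trifluoromethyl in place of hydrogen on an aromatic carbon, meta to a trifluoromethyl group, gives a 1.4-fold higher number from compound 3 to compound 4 (0.15 log units; within the scatter) and so does not move the number beyond the scatter at this position. Methyl in place of hydrogen on an oxygen on an aromatic ring gives a 1.9-fold higher number from compound 2 to compound 4 (0.27 log units; within the scatter) and likewise stays within the scatter, so neither single change can be told apart from repeat variation in this assay.

As far as these compounds go, it remains open whether an amine, a carboxylic acid or a longer chain at that aromatic carbon would shift the number beyond the scatter. Nothing shown bears on why these two steps are so small.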